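The compounds below may be only part of what the source reports. "The series", "measured", "known", "first", "only" and "open" are said of these compounds alone.

Measured so far in a functional assay on BGC-823 cells (Homo sapiens) for inhibition, read by CCK-8 assay, with a stated time of 48 h; on this read-out lower numbers stand for stronger inhibition and higher numbers for weaker inhibition:
compound 1 `COc1ccc(C2=NN(C3=NC(c4ccccc4)CS3)C(c3ccc4ccccc4c3)C2)cc1` gives 7250 nM;
compound 2 `Brc1ccc(C2=NN(C3=NC(c4ccccc4)CS3)C(c3ccc4ccccc4c3)C2)cc1` gives 13000 nM;
compound 3 `Clc1ccc(C2=NN(C3=NC(c4ccccc4)CS3)C(c3cccc4ccccc34)C2)cc1` gives 19600 nM.

Compound 3 stands at the highest of the three numbers. Its nearest neighbour is compound 2, whose value lies within the scatter of it, while compound 1 lies further off, beyond the scatter. Going by the values given here, the one step between measured compounds that differ in a single place is a 1.8-fold higher number from compound 1 to compound 2 (0.25 log units; within the scatter), a bromo in place of methoxy on an aromatic carbon, and it stays within the scatter.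

Compound 4 `Clc1ccc(C2=NN(C3=NC(c4ccccc4)CS3)C(c3ccc4ccccc4c3)C2)cc1` is not yet measured. It differs from compound 3 by naphthalen-2-yl in place of naphthalen-1-yl on a saturated ring carbon: the two have the same atoms, joined differently, and the change sits on a saturated ring carbon of the shared core. Among the compounds with values here, no measured step covers a move between naphthalen-1-yl and naphthalen-2-yl, so the expectation rests on indirect comparison. Within the data shown here, compound 4 resembles compound 2 in carrying naphthalen-2-yl, the two differing only in chloro against bromo, a pair for which no step is recorded; their values can only be set side by side once compound 4 is measured. Given this, no step beyond the scatter is expected, and compound 4 is estimated at 12000 nM in this assay, with a range of 5000 nM to 28000 nM, which would mean a step of a 1.6-fold lower number from compound 3 to compound 4 (0.21 log units; within the scatter).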

Compound 4, half-maximal inhibitory concentration: 14600 nM
Compound 4: middle estimate off by 1.2-fold (0.09 log units), on the low side; low and high end bracket the measured number.
By their numbers in this assay, from the lowest: compounds 1, 2, 4 and 3 (each within the scatter of the next, the first and the last beyond it).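

In this assay, going by these compounds alone, the only step at this position, naphthalen-2-yl in place of naphthalen-1-yl on a saturated ring carbon, gives a 1.3-fold lower number from compound 3 to compound 4 (0.13 log units; within the scatter) and stays within the scatter, so the assay does not separate these two groups, which have the same atoms joined differently. With naphthalen-2-yl held constant, chloro in place of bromo on an aromatic carbon gives a 1.1-fold higher number from compound 2 to compound 4 (0.05 log units; within the scatter) and chloro in place of methoxy gives a 2.0-fold higher number from compound 1 to compound 4 (0.30 log units; within the scatter) and both steps also stay within the scatter, so no single change among the compounds shown separates its pair. Nothing measured here offers an explanation for these steps.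

As far as these compounds go, it remains open whether a group of another kind on this saturated ring carbon, such as a pyridine ring, a dimethylamino-substituted phenyl or a benzoic acid, would give a step beyond the scatter in this assay for the compounds. Also open is what an amine or a carboxylic acid would do in place of the chloro of the 4-chlorophenyl group, since only chloro, bromo and methoxy are shown there.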